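A few compounds are considered here, and "the series" means these few. Any claim that something is new, unique, unknown or untested is made for them only; others in the source may bear on it.

Working notes on the series. Compound 1 `CCCCc1ccc2ncc(-c3nn[nH]n3)cc2c1` and compound 2 `O=c1c(-c2nn[nH]n2)c[nH]c2c(Br)cccc12` are the two members with results so far. In a functional assay on the whole organism (strain Sprague-Dawley) for inhibition, with Rattus norvegicus as the target (on this read-out higher numbers stand for an effect only at larger amounts of compound and lower numbers for an effect already at smaller amounts), compound 1 gives > 25 mg/kg, which is a limit of the assay and not a number. Compound 2 stands at > 10 mg/kg in this assay, likewise a limit. Among the measured compounds shown here, the evidence in hand therefore amounts to the limit of > 10 mg/kg in this assay, at which 1 of the 2 values shown sits, and (the limit of > 25 mg/kg in this assay, at which 1 of the 2 values shown sits), and no step between measured compounds can be read from it. Compound 3 `CC(C)Oc1cccc2c(=O)c(-c3nn[nH]n3)c[nH]c12` has not yet been tested in this assay. It differs from compound 2 by isopropoxy in place of bromo on an aromatic carbon. With nothing but limits to build on, the step that the limit leaves unreadable from compound 2 to compound 3 is expected to stay within the usual scatter, with no direction set. For compound 3 in this assay a minimum effective dose of 20 mg/kg is estimated, with a range from 5 mg/kg to 80 mg/kg, and a real chance that only a limit is reported again.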

Compound 3, minimum effective dose: 1.25 mg/kg
The estimate for compound 3 lay 16-fold (1.20 log units) above the measured number, and the stated range ends above it.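

In this assay, isopropoxy in place of bromo on an aromatic carbon gives an at least 8.0-fold lower number from compound 2 to compound 3 (0.90 log units; beyond the scatter), and compound 3 is the first member shown with a number and not a limit. Compound 2 stands at > 10 mg/kg, which is a limit of the assay and not a number, and the step therefore fixes only a minimum size. At this place, ortho to a fused ring and meta to a fused ring, the entry of 4 heavy atoms for 1 heavy atom, with 1 hydrogen-bond acceptor, goes with an effect at a measurable dose.

The compounds shown do not separate the part played by the oxygen from that of the branched chain, and a methoxy group or an isopropyl group on the same carbon would speak to that. On these data alone, how an amine or a longer alkoxy chain would fare at this place also remains open.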